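A few compounds are considered here, and "the series" means these few. Any claim that something is new, unique, unknown or untested is made for them only; others in the source may bear on it.

Measured so far in an assay on CHO-K1 cells for antagonist activity at adenosine receptor A1 (Homo sapiens), read by a beta-galactosidase reporter, with stated times of 15 min and 6 h; a lower number here means a stronger inhibitor, a higher number a weaker inhibitor:
- compound 1 `Nc1nc(-c2ccc(C(F)F)o2)nc2sc(CN3CCC(F)CC3)cc12`: compound 1 gives 1670 nM
- compound 2 `Nc1nc(-c2ccc(Cl)o2)nc2sc(CN3CCC(F)CC3)cc12`: compound 2 gives 1080 nM
- compound 3 `N#Cc1cccc(-c2nc(N)c3cc(CN4CCC(F)CC4)sc3n2)c1`: compound 3 gives 2950 nM

Among these three numbers compound 3 stands highest. One of its two steps stays within the usual scatter, a 1.8-fold higher number from compound 1 to compound 3 (0.25 log units; within the scatter), while the other goes modestly beyond it, a 2.7-fold higher number from compound 2 to compound 3 (0.44 log units; beyond the scatter). The remaining step between the two furan compounds, a 1.5-fold lower number from compound 1 to compound 2 (0.19 log units; within the scatter), also lies within the scatter.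

Compound 4 `N#Cc1ccc(-c2nc(N)c3cc(CN4CCC(F)CC4)sc3n2)cc1` is the next compound. It differs from compound 3 by 4-cyanophenyl in place of 3-cyanophenyl on an aromatic carbon. The nitrile thus stays on the same phenyl ring but moves to another carbon of it, and the two compounds hold the same atoms. Among the measured compounds shown here, none of the measured steps moves a substituent around a ring in this way; the only steps that touch this part of the structure exchange a substituted furan for the 3-cyanophenyl group, and both of those were small. Nothing in the data therefore points to a change in either direction, and for compound 4 the expected step is a 1.0-fold higher number from compound 3 to compound 4 (0.01 log units; within the scatter). For compound 4 the estimate in this assay is 3000 nM, expected to fall between 1000 nM and 9000 nM.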

Compound 4, inhibition constant: 8430 nM
The estimate for compound 4 lay 2.8-fold (0.45 log units) below the measured number, within the range that was stated.
By their numbers in this assay, from the lowest: compounds 2, 1 and 3 (each within the scatter of the next, the first and the last beyond it); then compound 4.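

Moving the nitrile around the phenyl ring, with the atoms unchanged, is not a neutral change in this assay: 4-cyanophenyl in place of 3-cyanophenyl gives a 2.9-fold higher number from compound 3 to compound 4 (0.46 log units; beyond the scatter) and so shows that the place of the nitrile on this ring affects the number, which no earlier step could show. Among the compounds shown here, the same group also stands apart from both furan compounds, with a 7.8-fold higher number from compound 2 to compound 4 (0.89 log units; beyond the scatter) and a 5.0-fold higher number from compound 1 to compound 4 (0.70 log units; beyond the scatter), so compound 4 is the weakest inhibitor of the four and the only one whose steps to all the others lie beyond the scatter. No measurement at hand explains why the place of the nitrile matters here.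

The compounds shown leave open whether this dependence on place belongs to the nitrile itself or would also appear with another group on the phenyl ring, such as a methoxy group or a carboxylic acid in the same two places. They also leave open how an unsubstituted phenyl ring at this position would compare with compound 3 and compound 4.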